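The compounds below may be only part of what the source reports. "The series", "measured", "known", "first", "only" and "open" are said of these compounds alone.

Compound 1 `CCCCCN1C(=O)C/C(=C\c2cccc(C(=O)NCCCC)c2)C1=O`: > 100000 nM
Compound 2 `Cc1ccc(NC(=O)c2cccc(/C=C3\CC(=O)N(c4ccccc4)C3=O)c2)cc1C`: > 100000 nM
Compound 3 `O=C(Nc1ccc(Cl)cc1)c1cccc(/C=C2\CC(=O)N(Cc3ccccc3)C2=O)c1`: > 100000 nM

Of the compounds shown here, three have been tested in an ADME assay on HCT-116 cells (Homo sapiens) for cytotoxicity, read by MTT assay, with a stated time of 72 h (on this read-out lower numbers stand for stronger inhibition and higher numbers for weaker inhibition), and none of them returned a number. For compound 1 the entry > 100000 nM is a limit of the assay. For compound 2 the entry > 100000 nM is likewise a limit. For compound 3 the entry > 100000 nM is also a limit. Compound 2 therefore stands where the other two stand, on the limit line (the limit of > 100000 nM in this assay, at which 3 of the 3 values shown sit), and no step between any pair of these compounds can be measured, so nothing can be said about how the shared core responds to the differences among them in this assay.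

The compound still to be tested is compound 4 `CCc1ccc(NC(=O)c2cccc(/C=C3\CC(=O)N(c4ccccc4)C3=O)c2)cc1`. It differs from compound 2 in one place: 4-ethylphenyl in place of 3,4-dimethylphenyl on an amide-type nitrogen. Among the compounds with values here, no measured step of this kind exists here. Since compound 2 sits on the limit and the two other measured compounds sit on the same limit, the expected step in this assay from compound 2 to compound 4 is none beyond the scatter, that is a number no higher from compound 2 to compound 4 (the limit leaves the size open). Compound 4 is accordingly expected to give 100000 nM in this assay, in a range from 40000 nM to 300000 nM, most probably reported again as a limit rather than a number.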

Compound 4, half-maximal inhibitory concentration: > 100000 nM
Compound 4 gave a limit, no number; the forecaster's own chance of this, stated with the estimate: 85%; the middle value sits exactly at the limit.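

In this assay compound 4 gives > 100000 nM, which is a limit and not a number. No step can therefore be read between compound 2 and compound 4, and the result joins the others on one line: the limit of > 100000 nM in this assay, at which 4 of the 4 values shown sit.

The compounds shown leave open how far 4-ethylphenyl and 3,4-dimethylphenyl on the amide-type nitrogen differ in this assay.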